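The source may report more compounds than this note shows. Statements on the series, on what has been measured and on what is new or still open speak of the compounds shown alone.

Measured compounds in a functional assay on HT-29 cells (Homo sapiens) for cytotoxicity, read by MTT assay, with a stated time of 72 h; on this read-out lower numbers stand for stronger inhibition of growth and higher numbers for weaker inhibition of growth:
- compound 1, `C[Se]/C(=N\C(=O)c1cc2ccccc2s1)NC(=O)c1cc2ccccc2s1`: compound 1 gives > 100000 nM
- compound 2, `CS/C(=N\C(=O)c1csc([N+](=O)[O-])c1)NC(=O)c1csc([N+](=O)[O-])c1`: compound 2 gives > 100000 nM
- compound 3, `C[Se]/C(=N\C(=O)c1ccco1)NC(=O)c1ccco1`: compound 3 gives > 100000 nM

Each of these three values is a limit of this assay, not a number; compound 1 therefore has only a limit, and the two other measured values are limits as well, so that compound 1 cannot be placed in any order against compound 2 or compound 3. This is the limit of > 100000 nM in this assay, at which 3 of the 3 values shown sit.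

The unmeasured compound is compound 4, `CS/C(=N\C(=O)c1cc2ccccc2s1)NC(=O)c1cc2ccccc2s1`. It differs from compound 1 by a group of 2 heavy atoms (1 carbon, 1 sulfur; no ring) in place of a group of 2 heavy atoms (1 carbon, 1 selenium; no ring), on a carbon with a double bond to nitrogen. Within the compounds shown, the methylsulfanyl group is present in compound 2, which also sits at the limit, and the selenium-bearing analogues compound 1 and compound 3 sit there too. Among the measured compounds shown here, no measured pair gives a step that would show how large this exchange acts in this assay.

The expected step is a step that the limit leaves unreadable from compound 1 to compound 4, which is to say none beyond the usual scatter. Compound 4 is estimated at 200000 nM, with a range from 70000 nM to 1000000 nM, and the assay is expected to report only a limit again.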

Compound 4, concentration for total growth inhibition: 88200 nM
Compound 4: the middle estimate sits 2.3-fold (0.36 log units) above what was measured; measured number inside the range.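

In this assay, among the compounds shown here, compound 4 gives 88200 nM, the only value shown that is not a limit. Exchanging the selenium-bearing group for methylsulfanyl, on a carbon with a double bond to nitrogen, gives an at least 1.1-fold lower number from compound 1 to compound 4 (0.05 log units; that floor lies within the scatter). Only this floor can be read, so the true size of the step remains unknown, because compound 1 has no number of its own: the limit of > 100000 nM in this assay, at which 3 of the 4 values shown sit.

Going by these compounds, whether the same exchange gives a readable number on the core of compound 3 stays open. So does the effect of an amine or a longer chain at this carbon.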